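This account rests on a few compounds, and the source may have more. Where it says the series, first, only, none or still open, it means among the compounds named here.

In a functional assay on HepG2 cells (Homo sapiens) for inhibition, read by MTT assay, with a stated time of 48 h (a lower number here means a stronger inhibitor, a higher number a weaker inhibitor), compound 3 (`CCOC(=O)C1=C(N/N=C(/Cl)c2ccc([N+](=O)[O-])cc2)Nc2[nH]nc(C)c2C1c1ccc(N(C)C)cc1`) gives 55500 nM and sits level with compound 1 (`CCOC(=O)C1=C(N/N=C(\C#N)C(N)=O)Nc2[nH]nc(C)c2C1c1ccc(N(C)C)cc1`), which gives 48400 nM on the same scale. Compound 2 (`CCOC(=O)C1=C(N/C=N/c2ncc(-c3ccccc3)s2)Nc2[nH]nc(C)c2C1c1ccc(N(C)C)cc1`) gives a clearly lower number, 9790 nM, beyond the scatter of the other two.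

Compound 4 (`CCOC(=O)C1=C(N/N=C(/C(=O)Br)c2ccc(Cl)cc2)Nc2[nH]nc(C)c2C1c1ccc(N(C)C)cc1`) keeps the shared core and exchanges one group on the amine nitrogen, and the change from compound 3 is a group of 12 heavy atoms (8 carbon, 1 nitrogen, 1 oxygen, 1 chlorine, 1 bromine; one six-membered aromatic ring of carbon only) in place of a group of 12 heavy atoms (7 carbon, 2 nitrogen, 2 oxygen, 1 chlorine; one six-membered aromatic ring of carbon only), on an amine nitrogen with nothing else altered. Both groups hold one six-membered aromatic ring of carbon only.

Going by the values given here, the one measured step that bears on this also exchanges a group on an amine nitrogen, and it reads a 1.1-fold higher number from compound 1 to compound 3 (0.06 log units; within the scatter) and so shows no real movement. Compound 2, at 9790 nM with another group on that nitrogen, keeps the lower end of the range open.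

On that basis the expected change is a 1.2-fold lower number from compound 3 to compound 4 (0.09 log units; within the scatter) and no shift beyond the scatter is expected. For compound 4 the estimated value is 45000 nM, with an expected range from 18000 nM to 100000 nM.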

Compound 4, half-maximal inhibitory concentration: 50300 nM
Estimate against measurement, compound 4: 1.1-fold (0.05 log units) below; the range from low to high includes it.
By their numbers in this assay, from the lowest: compound 2; then compounds 1, 4 and 3 (each within the scatter of the next).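

In this assay, the exchange of one ring-bearing group for another on the amine nitrogen gives a 1.1-fold lower number from compound 3 to compound 4 (0.04 log units; within the scatter), so this second group, which carries bromine, adds a new case of no real movement. The ringless group of compound 1 compares in the same way with the new group, at a 1.0-fold higher number from compound 1 to compound 4 (0.02 log units; within the scatter), so three quite different groups at this position now sit level, while compound 2 stays apart at 9790 nM. No measurement is available that explains this flat behaviour.

On these data alone, whether a group ending in an amine or a carboxylic acid on this nitrogen would shift the number remains open. Also open, as far as these compounds go, is which part of the group in compound 2, with its thiazole-free comparison still lacking, goes with its lower value.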